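A few compounds are considered here, and "the series" means these few. Any claim that something is new, unique, unknown or untested is made for them only; others in the source may bear on it.

Compound 1 `COc1ccc(S(=O)(=O)NCCCNc2nccc(-c3[nH]c(-c4ccccc4)nc3-c3ccc(Cl)c(OC)c3)n2)cc1` gives 1800 nM in a functional assay on LOX IMVI cells (Homo sapiens) for cytotoxicity, read by MTT assay, with a stated time of 24 h; on this read-out lower numbers stand for stronger inhibition and higher numbers for weaker inhibition. Compound 2 `COc1cc(-c2nc(-c3ccccc3)[nH]c2-c2ccnc(NCCCNS(=O)(=O)c3cccc4ccccc34)n2)ccc1Cl` carries the change naphthalen-1-yl in place of 4-methoxyphenyl on a sulfonyl sulfur and gives 13500 nM, a step of a 7.5-fold higher number from compound 1 to compound 2 (0.88 log units; beyond the scatter). Compound 3 `COc1ccc(S(=O)(=O)NCCCNc2nccc(-c3[nH]c(-c4ccccc4)nc3-c3ccc(F)c(O)c3)n2)cc1` differs from compound 1 in its core by 4-fluoro-3-hydroxyphenyl in place of 4-chloro-3-methoxyphenyl on an aromatic carbon, and compound 3 gives 13900 nM, a step of a 7.7-fold higher number from compound 1 to compound 3 (0.89 log units; beyond the scatter). Compound 4 `O=S(=O)(NCCCNc1nccc(-c2[nH]c(-c3ccccc3)nc2-c2ccc(F)c(O)c2)n1)c1cccc2ccccc12` is not yet measured; it relates to compound 3 through (naphthalen-1-yl in place of 4-methoxyphenyl on a sulfonyl sulfur), the same change seen from compound 1 to compound 2, since the two sulfonyl positions are described in identical words. He expects the step from compound 3 to compound 4 to be a 4.3-fold higher number from compound 3 to compound 4 (0.64 log units; beyond the scatter), set beside a 7.5-fold higher number from compound 1 to compound 2 (0.88 log units; beyond the scatter), because compound 3 already sits at 13900 nM and the assay may not resolve a much higher number. His estimate for compound 4 is 60000 nM, between 20000 nM and 180000 nM.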

Compound 4, half-maximal inhibitory concentration: 3710 nM
The estimate for compound 4 lay 16-fold (1.21 log units) above the measured number, and the stated range ends above it.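

In this assay, naphthalen-1-yl in place of 4-methoxyphenyl on a sulfonyl sulfur does not carry from one core to the other, and on the second core the direction reverses, with a 3.7-fold lower number from compound 3 to compound 4 (0.57 log units; beyond the scatter): the same change on two cores in this assay, a 7.5-fold higher number (0.88 log units; beyond the scatter) from compound 1 to compound 2 and a 3.7-fold lower number (0.57 log units; beyond the scatter) from compound 3 to compound 4, 28-fold (1.45 log units) apart, beyond the scatter of two such steps. The change to 4-fluoro-3-hydroxyphenyl from 4-chloro-3-methoxyphenyl on an aromatic carbon also reverses, with a 3.6-fold lower number from compound 2 to compound 4 (0.56 log units; beyond the scatter): the same change on two cores in this assay, a 7.7-fold higher number (0.89 log units; beyond the scatter) from compound 1 to compound 3 and a 3.6-fold lower number (0.56 log units; beyond the scatter) from compound 2 to compound 4, 28-fold (1.45 log units) apart, beyond the scatter of two such steps. These four compounds show that neither change can be read across as a fixed step, but they do not show why, and one pair per core gives no rule for other cores.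

The compounds shown leave open whether the fluorine or the hydroxyl matters more, which a 4-chloro-3-hydroxyphenyl or 4-fluoro-3-methoxyphenyl group would separate. On these data alone, it is also open how a benzyl or methyl group on the sulfonyl sulfur would behave on either core.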